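Aryl variation on the five-membered ring nitrogen

This account rests on a few compounds, and the source may have more. Where it says the series, first, only, none or still open, it means among the compounds named here.

compound 1 `N#CC1=C(N)Oc2c(N)cc3nc4ccccc4nc3c2C12C(=O)N(Cc1cnnn1-c1ccccc1Cl)c1ccccc12`: 29800 nM
compound 2 `N#CC1=C(N)Oc2c(N)cc3nc4ccccc4nc3c2C12C(=O)N(Cc1cnnn1-c1ccccc1Br)c1ccccc12`: 27400 nM
compound 3 `CC(=O)Nc1ccc(-n2nncc2CN2C(=O)C3(C(C#N)=C(N)Oc4c(N)cc5nc6ccccc6nc5c43)c3ccccc32)cc1`: > 50000 nM

In a functional assay on A549 cells (Homo sapiens) for antiproliferative activity, read by MTT assay, with a stated time of 48 h (a higher number here means a weaker inhibitor, a lower number a stronger inhibitor), compound 1 and compound 2 sit close together; a 1.1-fold lower number from compound 1 to compound 2 (0.04 log units; within the scatter). Compound 3 gives only a limit of this assay, > 50000 nM, as recorded by the limit of > 50000 nM in this assay, at which 1 of the 3 values shown sits. Compound 4 `COc1ccccc1-n1nncc1CN1C(=O)C2(C(C#N)=C(N)Oc3c(N)cc4nc5ccccc5nc4c32)c2ccccc21` is not yet measured; (2-methoxyphenyl in place of 4-acetamidophenyl on an aromatic nitrogen). The measured steps that bear on this run the other way: an at least 1.6-fold higher number from compound 1 to compound 3 (0.22 log units; that floor lies within the scatter) and an at least 1.8-fold higher number from compound 2 to compound 3 (0.26 log units; that floor lies within the scatter). In compound 4 a 2-methoxyphenyl again stands where compound 1 and compound 2 carry 2-chlorophenyl and 2-bromophenyl, so a number near those two is expected for compound 4. The expected step is an at least 1.4-fold lower number from compound 3 to compound 4 (0.15 log units; that floor lies within the scatter), which need not exceed the scatter. Compound 4 is estimated at 35000 nM, with a range of 15000 nM to 90000 nM.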

Compound 4, half-maximal inhibitory concentration: 37500 nM
Estimate against measurement, compound 4: 1.1-fold (0.03 log units) below; the measured number falls inside the stated range.
By their numbers in this assay, from the lowest: compounds 2, 1 and 4 (each within the scatter of the next). At a limit, above all of these: compound 3.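

Methoxy in place of bromo or chloro gives a 1.4-fold higher number from compound 2 to compound 4 (0.14 log units; within the scatter) and a 1.3-fold higher number from compound 1 to compound 4 (0.10 log units; within the scatter), so in this assay a group that is not a halogen reads the same as the two halogens. Against the 4-acetamidophenyl the only reading is a floor, an at least 1.3-fold lower number from compound 3 to compound 4 (0.12 log units; that floor lies within the scatter), so no difference between these two aryl groups is shown. The value of compound 3 is a limit and not a number: the limit of > 50000 nM in this assay, at which 1 of the 4 values shown sits.

Open, from the compounds shown here alone, is whether an amine or a carboxylic acid on this phenyl ring would move the number beyond the scatter. Also open, going by these compounds, is what a simple alkyl chain would do in place of the aryl group on the aromatic nitrogen.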